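The compounds below may be only part of what the source reports. "The series", "measured", "known", "first", "only" and "open" are said of these compounds alone.

Compound 1 `CCc1c(OC)nc2nc(-c3nnc(C)o3)cn2c1C` carries an ethyl group and a 5-methyl-1,3,4-oxadiazol-2-yl group on a shared core. In a functional assay on the whole organism with Rattus norvegicus as the target (on this read-out higher numbers stand for an effect only at larger amounts of compound and lower numbers for an effect already at smaller amounts), compound 1 gives 2 mg/kg. Compound 2 `C=CCc1c(OC)nc2nc(-c3nnc(C)o3)cn2c1C` gives 10 mg/kg in this assay, and a 5.0-fold higher number from compound 1 to compound 2 (0.70 log units; beyond the scatter). Compound 3 `C/C=C/c1c(OC)nc2nc(-c3nnc(C)o3)cn2c1C` reports only a limit in this assay, > 50 mg/kg, which is the limit of > 50 mg/kg in this assay, at which 1 of the 3 values shown sits. Of the two full numbers, compound 1 has the lowest, so among these it acts at the smallest amount of compound.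

Compound 4 `CCc1c(OC)nc2nc(-c3cc(C)no3)cn2c1C` differs from compound 1 at another place: 3-methyl-1,2-oxazol-5-yl in place of 5-methyl-1,3,4-oxadiazol-2-yl on an aromatic carbon. The measured steps all alter the ethyl chain rather than this ring: an at least 25-fold higher number from compound 1 to compound 3 (1.39 log units; beyond the scatter), and an at least 5.0-fold higher number from compound 2 to compound 3 (0.69 log units; beyond the scatter). None of them touches the five-membered ring exchanged here, so they give no direct guide to the size or direction of the change. An exchange of one small aromatic ring for another is expected to move the number somewhat, in either direction, with the usual scatter allowed for. Compound 4 is therefore estimated at 5 mg/kg in this assay, within 1 mg/kg to 25 mg/kg. In other words, a 2.5-fold higher number from compound 1 to compound 4 (0.40 log units; beyond the scatter) is the expected outcome.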

Compound 4, minimum effective dose: 50 mg/kg
For compound 4 the middle estimate is 10-fold (1.00 log units) below the measured one; the measured number lies above the stated range.
By their numbers in this assay, from the lowest: compound 1; then compound 2; then compound 4.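

In this assay, going by these compounds alone, the earlier steps all altered the chain on the shared core, whereas this one shows that the other position, the five-membered aromatic ring, is also sensitive: putting 3-methyl-1,2-oxazol-5-yl in place of 5-methyl-1,3,4-oxadiazol-2-yl gives a 25-fold higher number from compound 1 to compound 4 (1.40 log units; beyond the scatter). The exchange is small on paper, since both groups have 6 heavy atoms and no hydrogen-bond donors, and the entering ring has one nitrogen where the leaving ring has two, so a close match in atom counts does not guarantee a close match in dose. Of the compounds shown, only compound 3 stands as a limit and not as a number: the limit of > 50 mg/kg in this assay, at which 1 of the 4 values shown sits.

No measured property of either ring is shown, so what in the exchange produces this step stays unknown. Also open, going by these compounds, are whether a nitrile or a primary amide at this aromatic carbon would keep the effect at doses as small as those of compound 1, and whether the same ring exchange would cost as much with the allyl chain of compound 2.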